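This account rests on a few compounds, and the source may have more. Where it says the series, first, only, none or still open, it means among the compounds named here.

Compound 1 `O=C1Oc2ccccc2N/C1=C\C(=O)c1cccc(Cl)c1` gives 1610000 nM in an ADME assay on Vero cells (Chlorocebus sabaeus) for cytotoxicity, read by MTT assay, with a stated time of 72 h; a lower number here means that less compound is tolerated, a higher number that more compound is tolerated.
Compound 2 `O=C1Oc2ccccc2N/C1=C\C(=O)c1ccccc1Cl` gives 1570000 nM in this assay.
Compound 3 `COC(=O)/C=C1\Nc2ccccc2OC1=O` gives only a limit of the assay, > 2280000 nM, in this assay.

Compound 3 therefore stands at the limit of > 2280000 nM in this assay, at which 1 of the 3 values shown sits, and no number is known for it. Compound 4 `COC(=O)/C=C1\Nc2ccc(Cl)cc2OC1=O` differs from it in one place: chloro in place of hydrogen on an aromatic carbon. Within the data shown here, none of the measured steps touches that ring. The steps of an at least 1.4-fold higher number from compound 1 to compound 3 (0.15 log units; that floor lies within the scatter) and an at least 1.4-fold higher number from compound 2 to compound 3 (0.16 log units; that floor lies within the scatter) change the group on the carbonyl carbon, and the step of a 1.0-fold lower number from compound 1 to compound 2 (0.01 log units; within the scatter) moves a chloro within a phenyl on that carbon; all three lie within the scatter. For compound 4 no step beyond the scatter is expected, so the change from compound 3 to compound 4 is estimated as an at least 1.1-fold lower number from compound 3 to compound 4 (0.05 log units; that floor lies within the scatter). Compound 4 is expected to give about 2000000 nM in this assay, between 1000000 nM and 4000000 nM.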

Compound 4, half-maximal cytotoxic concentration: 1600000 nM
Beside the measured number, compound 4's estimate is 1.3-fold (0.10 log units) above it, and the stated range covers the measured number.
By their numbers in this assay, from the lowest: compounds 2, 4 and 1 (each within the scatter of the next). At a limit, above all of these: compound 3.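

Chloro in place of hydrogen on this aromatic carbon, meta to a fused ring and para to a fused ring, is the first change shown on this part of the core, and in this assay it gives an at least 1.4-fold lower number from compound 3 to compound 4 (0.15 log units; that floor lies within the scatter). Compound 3 remains at a limit, so only this floor can be read and the true size of the step stays unknown: the limit of > 2280000 nM in this assay, at which 1 of the 4 values shown sits.

Going by these compounds, it remains open whether an amine or a bromo on this carbon would read differently. Also open, on these data alone, is whether chloro here would behave alike with a 2-chlorophenyl on the carbonyl carbon.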